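This account rests on a few compounds, and the source may have more. Where it says the series, first, only, none or still open, it means among the compounds named here.

Measured so far:
compound 1 `COC(=O)C1=C(C)NC(=O)NC1c1ccoc1`: 8%
compound 2 `COC(=O)C1=C(C)N(C)C(=O)NC1c1ccco1`: 45%

In an assay on membranes from CHO cells for displacement of a labelled ligand from adenosine receptor A1 (Homo sapiens), read by scintillation counting, with a stated time of 60 min, tested at 1 uM (a lower number here means less inhibition, a higher number more inhibition at the concentration tested (going by the name of the read-out)), compound 1 gives 8% and compound 2 gives 45%. Compound 2 stands highest of the two numbers; its nearest neighbour is compound 1, whose number lies below it by a distance beyond the scatter. For the measured compounds named here, compound 1 and compound 2 differ from each other in more than one place, so no single step between measured compounds is available for the change now considered.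

Compound 3 `COC(=O)C1=C(C)N(C)C(=O)NC1c1ccoc1` differs from compound 2 by furan-3-yl in place of furan-2-yl on a saturated ring carbon. Compound 3 thus shares the furan-3-yl of compound 1 while otherwise matching compound 2. Going by the values given here, the only measured furan-3-yl compound, compound 1, gives 8%, which is the lower of the two numbers, so a downward step is expected, but its size is uncertain. The step expected is a number 20 percentage points lower from compound 2 to compound 3 (beyond the scatter), a moderate loss beyond the scatter. Compound 3 is therefore estimated at 25%, with a range from 5% to 45%.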

Compound 3, a percentage reported as inhibition, at one concentration (the size of the read-out at that concentration, not a potency): 15%
Compound 3: the middle estimate sits 10 percentage points above what was measured; the range from low to high includes it.
By their numbers in this assay, from the lowest: compounds 1 and 3 (each within the scatter of the next); then compound 2.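

In this assay, furan-3-yl in place of furan-2-yl on the saturated ring carbon gives a step beyond the scatter (a number 30 percentage points lower from compound 2 to compound 3 (beyond the scatter)), so in this pair the change of furan attachment alone separates the two numbers. With furan-3-yl held constant, methyl in place of hydrogen on the amide-type nitrogen in a ring gives a step within the scatter (a number 7 percentage points higher from compound 1 to compound 3 (within the scatter)), so this pair shows no separable effect of that methyl. No measurement among the data given explains either step.

The compounds shown leave open whether furan-2-yl also stands apart from furan-3-yl with hydrogen on that nitrogen. On these data alone, it also remains open how a phenyl ring or an aminomethyl group on the same saturated ring carbon would compare with either furan.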